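Series notes: aryl variation on the thioether side chain

The source may hold more compounds than are shown below. What is called first, only, known or untested is meant among the compounds shown, and "the series" means these compounds.

Compound 1 `CC(Sc1nc2c(cnn2C)c(=O)n1-c1ccccc1)c1cccnc1` and compound 2 `CC(Sc1nc2c(cnn2C)c(=O)n1-c1ccccc1)c1cccc(O)c1` share one core and differ only in the aryl group on the side chain. In an assay on isolated protein for inhibition of Retinaldehyde dehydrogenase 3 (Homo sapiens) (a higher number here means a weaker inhibitor, a lower number a stronger inhibitor), compound 1 gives 95 nM; in this assay compound 2 gives 91 nM. The step of a 1.0-fold lower number from compound 1 to compound 2 (0.02 log units; within the scatter) shows that the two aryl groups at that position give numbers that cannot be told apart, and compound 2 stands together with compound 1 within the scatter, so neither is called the stronger inhibitor.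

Compound 3 `C[C@H](Sc1nc2c(cnn2C)c(=O)n1-c1ccccc1)c1ccccc1` is not yet measured in this assay. It differs from compound 2 as follows: a group of 8 heavy atoms (8 carbon; one six-membered aromatic ring of carbon only) in place of a group of 9 heavy atoms (8 carbon, 1 oxygen; one six-membered aromatic ring of carbon only), on a sulfur, so that the 1-phenylethyl group now carries a defined stereocentre. For the measured compounds named here, the one measured step that bears on this change, the exchange of aryl groups at the same position from compound 1 to compound 2, was flat. Going by the values given here, on that basis the expected step of a 1.2-fold higher number from compound 2 to compound 3 (0.08 log units; within the scatter) is small and not beyond the scatter, with no firm direction; the single flat step is thin ground for a tighter call. Compound 3 is therefore expected to give about 110 nM in this assay, with a range from 45 nM to 270 nM.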

Compound 3, half-maximal inhibitory concentration: 1640 nM
For compound 3 the middle estimate is 15-fold (1.17 log units) below the measured one, and the stated range ends below it.
By their numbers in this assay, from the lowest: compounds 2 and 1 (each within the scatter of the next); then compound 3.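

The flat step between compound 1 and compound 2 did not show that this position tolerates any aryl group: in this assay, the side chain without a ring nitrogen or hydroxyl gives an 18-fold higher number from compound 2 to compound 3 (1.26 log units; beyond the scatter) and a 17-fold higher number from compound 1 to compound 3 (1.24 log units; beyond the scatter). The two steps agree in size, so the pyridin-3-yl and 3-hydroxyphenyl forms stand together against the 1-phenylethyl group, which counts 0 hydrogen-bond donors and 0 hydrogen-bond acceptors, while the group it replaces in compound 2 counts 1 of each; compound 3 also has 1 defined stereocentre, so both steps carry that difference along with the change of aryl group. Nothing available explains the loss of inhibition at this position.

The compounds shown leave open how much of the loss belongs to the absent ring substituent or ring nitrogen and how much to the defined stereocentre, as the other stereoisomer of compound 3 is not among them. They also leave open whether a methoxy group or an amine on the aryl ring would keep the numbers of compound 1 and compound 2 or follow compound 3.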